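From a Dimethylamino Chain to a Propargyl Amide

The source may report more compounds than this note shows. Statements on the series, on what has been measured and on what is new or still open speak of the compounds shown alone.

Compound 1 `CCn1c(C(=O)NCCCN(C)C)ccc1C(CC)(CC)c1ccc(OCC(=O)C(C)(C)C)c(C)c1`: 1600 nM
Compound 2 `CCOC(=O)CN(C)C(=O)c1ccc(C(CC)(CC)c2ccc(OCC(O)C(C)(C)C)c(C)c2)n1CC`: 25500 nM
Compound 3 `CCn1c(C(=O)NCCCN(C)C)ccc1C(CC)(CC)c1ccc(OCC(O)C(C)(C)C)c(C)c1`: 3100 nM

These values come from a functional assay on PC-3 cells (Homo sapiens), read by MTT assay, with a stated time of 48 h; a lower number here means a stronger inhibitor, a higher number a weaker inhibitor. Compound 3 cannot be told apart from compound 1, with a 1.9-fold higher number from compound 1 to compound 3 (0.29 log units; within the scatter) between them, but it stands clearly apart from compound 2, with an 8.2-fold lower number from compound 2 to compound 3 (0.92 log units; beyond the scatter) as the gap.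

Compound 4 `C#CCNC(=O)c1ccc(C(CC)(CC)c2ccc(OCC(O)C(C)(C)C)c(C)c2)n1CC` alters the amide chain of compound 3: ethynyl in place of 2-(dimethylamino)ethyl on a saturated chain carbon bound to an amide-type nitrogen. Put simply, ethynyl takes the place of 2-(dimethylamino)ethyl on a saturated chain carbon bound to an amide-type nitrogen.

The step to compound 3 from compound 1 concerns a different group and offers little guidance here. The more relevant evidence is an 8.2-fold lower number from compound 2 to compound 3 (0.92 log units; beyond the scatter). That change is on the same carbonyl carbon. Like compound 2, compound 4 has no dimethylamino group, so a higher number is expected, though the new chain differs from that of compound 2. The expected change in this assay is a 3.9-fold higher number from compound 3 to compound 4 (0.59 log units; beyond the scatter) and is beyond the scatter. The estimate for compound 4 is 12000 nM, with an expected range from 4000 nM to 35000 nM and no firmer claim possible from three measured compounds.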

Compound 4, half-maximal inhibitory concentration: 16200 nM
Compound 4: the middle estimate sits 1.4-fold (0.13 log units) below what was measured, and the stated range covers the measured number.
By their numbers in this assay, from the lowest: compounds 1 and 3 (each within the scatter of the next); then compounds 4 and 2 (each within the scatter of the next).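

In this assay, the result gives the amide chain a second test: replacing 3-(dimethylamino)propyl with propargyl gives a 5.2-fold higher number from compound 3 to compound 4 (0.72 log units; beyond the scatter), a step beyond the scatter, so a second chain without the dimethylamino group also sits clearly above compound 3. The propargylamino and ((ethoxycarbonyl)methyl)(methyl)amino groups on the carbonyl carbon show a 1.6-fold lower number from compound 2 to compound 4 (0.20 log units; within the scatter), so these two quite different chains cannot be told apart here. No measurement at hand explains the gap from compound 3.

Still open, on these data alone, is whether the dimethylamino group or the length of the chain matters more: a plain propyl chain with no amine, or a longer chain ending in the same dimethylamino group, would help separate the two. It is also unknown how the propargyl amide behaves with (tert-butyl)carbonyl in place of 1-hydroxy-2,2-dimethylpropyl.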